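Chain Length and Inhibition: From Compound 2 to Compound 3

A few compounds are considered here, and "the series" means these few. Any claim that something is new, unique, unknown or untested is made for them only; others in the source may bear on it.

Compound 1 `CCCSC[C@H](NC(C)=O)C(=O)CCl`: 8000 nM
Compound 2 `CCCCCCCCCCSC[C@H](NC(C)=O)C(=O)CCl`: 3400 nM

In a functional assay on MOLT-3 cells (Homo sapiens) (on this read-out higher numbers stand for weaker inhibition and lower numbers for stronger inhibition), compound 2 gives the lowest of the two numbers, with compound 1 giving the nearer and higher value. Compound 3 `CCCCCCCCCCCCCCCCCCCCSC[C@H](NC(C)=O)C(=O)CCl` differs from compound 2 by decyl in place of hydrogen on a saturated chain carbon, ten or more bonds along the chain from a sulfur. For the measured compounds named here, the one measured step that bears on this change is a 2.4-fold lower number from compound 1 to compound 2 (0.37 log units; beyond the scatter), a modest gain for a comparable lengthening of the same chain. A further lengthening is therefore expected to bring only a small step, if any beyond the scatter. Compound 3 is estimated at 3000 nM (range 1000 nM to 10000 nM), which corresponds to an expected step of a 1.1-fold lower number from compound 2 to compound 3 (0.05 log units; within the scatter).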

Compound 3, half-maximal inhibitory concentration: > 100000 nM
Compound 3: only a limit was reported; the forecaster's own chance of this, stated with the estimate: 10%; middle value at least 33-fold (1.52 log units) away from the limit.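

In this assay, lengthening the chain does not keep lowering the number: adding decyl reverses the direction of the earlier step (a 2.4-fold lower number from compound 1 to compound 2 (0.37 log units; beyond the scatter)) and gives a large change the other way (an at least 29-fold higher number from compound 2 to compound 3 (1.46 log units; beyond the scatter)). This position therefore has an upper limit on chain length, which the two shorter chains did not reveal. The reading for compound 3 is a limit of the assay, not a number: the limit of > 100000 nM in this assay, at which 1 of the 3 values shown sits.

The compounds shown leave open where along the chain the reversal sets in, which a tetradecyl chain could help to place. They also leave open whether a long chain carrying an amine or a carboxylic acid would behave the same way.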